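The source may report more compounds than this note shows. Statements on the series, on what has been measured and on what is new or still open speak of the compounds shown alone.

Working notes on the series in a functional assay on U-373MG ATCC cells (Homo sapiens) for inhibition, read by MTT assay, with a stated time of 72 h; a higher number here means a weaker inhibitor of growth, a lower number a stronger inhibitor of growth. Compound 1 `Cc1cn([C@@H]2O[C@H](CO[Si](c3ccccc3)(c3ccccc3)C(C)(C)C)[C@@H](O)[C@H]2O)c(=O)[nH]c1=O` gives 25000 nM and compound 2 `CC(C)(C)[Si](OC[C@H]1O[C@@H](n2ccc(N)nc2=O)[C@H](O)[C@@H]1O)(c1ccccc1)c1ccccc1` gives 28000 nM. Going by the values given here, compound 2 therefore stands level with the only other measured number, since a 1.1-fold higher number from compound 1 to compound 2 (0.05 log units; within the scatter). Compound 3 `CC(C)(C)[Si](OC[C@H]1O[C@@H](n2cnc3c(N)ncnc32)[C@H](O)[C@@H]1O)(c1ccccc1)c1ccccc1` keeps the core of compound 2 and alters one place, on a saturated ring carbon next to the ring oxygen: a group of 10 heavy atoms (5 carbon, 5 nitrogen; one five-membered aromatic ring with 2 hetero atoms, one six-membered aromatic ring with 2 hetero atoms) in place of a group of 8 heavy atoms (4 carbon, 3 nitrogen, 1 oxygen; one six-membered aromatic ring with 2 hetero atoms), on a saturated ring carbon. Among the compounds with values here, one measured step bears on this place, the exchange at that same carbon in a 1.1-fold higher number from compound 1 to compound 2 (0.05 log units; within the scatter), and it stayed within the scatter. Within the data shown here, no measured compound carries a group with a five-membered aromatic ring, so that part of the change remains untested. No step beyond the scatter is therefore expected in this assay, and the estimate is a 1.1-fold lower number from compound 2 to compound 3 (0.05 log units; within the scatter). For compound 3 the estimated value is 25000 nM, with an expected range of 11000 nM to 55000 nM.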

Compound 3, concentration for 50% growth inhibition: 44000 nM
Estimate against measurement, compound 3: 1.8-fold (0.25 log units) below; measured number inside the range.
By their numbers in this assay, from the lowest: compounds 1, 2 and 3 (each within the scatter of the next).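

In this assay, the exchange on the saturated ring carbon next to the ring oxygen now extends to a group with a five-membered aromatic ring fused into the picture, and both new steps stay within the scatter (a 1.6-fold higher number from compound 2 to compound 3 (0.20 log units; within the scatter); a 1.8-fold higher number from compound 1 to compound 3 (0.25 log units; within the scatter)). The three groups at this carbon, of 8, 9 and 10 heavy atoms, are therefore not separated by this read-out, and the added five-membered aromatic ring brings no step beyond the scatter in these compounds. Nothing available explains this flat reading.

Going by these compounds, whether a group without an aromatic ring at this carbon, such as a simple amine or a carboxylic acid, would give a step beyond the scatter remains open. Also open, on these data alone, is whether a methoxy group in place of a ring hydroxy group would change the number on the shared core.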